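Adding an ethynyl to the chain of compound 2

This account rests on a few compounds, and the source may have more. Where it says the series, first, only, none or still open, it means among the compounds named here.

compound 1 `Cn1c2cnc1OCCCCCCCCCOc1ccccc1-2`: "not determined" (no result reported)
compound 2 `CCCCOc1ncc(-c2ccccc2OC)n1C`: 71000 nM

Both compounds were taken into a functional assay on B16-F10 cells (Mus musculus) for inhibition, read by colorimetric assay and MTT assay, with a stated time of 72 h; a higher number here means a weaker inhibitor, a lower number a stronger inhibitor. For the measured compounds named here, no result is reported for compound 1, so compound 2 carries the only number there, 71000 nM, and it cannot be ranked against anything. Compound 3 `C#CCCCCOc1ncc(-c2ccccc2OC)n1C` keeps the core of compound 2 and differs from it in one place. That difference is ethynyl in place of hydrogen on a saturated chain carbon, four bonds along the chain from an oxygen on an aromatic ring, with ethynyl in place of hydrogen on a saturated chain carbon, four bonds along the chain from an oxygen on an aromatic ring. Going by the values given here, no measured pair shows what such a change does. With compound 2 at 71000 nM as the sole anchor, only a small move toward stronger inhibition is expected, perhaps none beyond the scatter. The expected step is a 1.4-fold lower number from compound 2 to compound 3 (0.15 log units; within the scatter). The value of compound 3 is estimated at 50000 nM, with an expected range from 18000 nM to 130000 nM.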

Compound 3, half-maximal inhibitory concentration: 34000 nM
Compound 3: middle estimate off by 1.5-fold (0.17 log units), on the high side; measured number inside the range.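

In this assay, for the compounds shown here, the ethynyl gives a 2.1-fold lower number from compound 2 to compound 3 (0.32 log units; beyond the scatter) and so provides the first measured change at this position, a saturated chain carbon four bonds along the chain from an oxygen on an aromatic ring. The step shows that this carbon can carry the two added carbons and their triple bond with no loss of inhibition, a modest gain beyond the scatter, although compound 3 still reads 34000 nM in absolute terms. Nothing available explains why the number falls.

The compounds shown leave open whether the triple bond itself or the added chain length carries this step, a question that a plain hexyl chain at the same place would help to settle. They also leave open how an amine or a carboxylic acid would read at this position.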